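The source may hold more compounds than are shown below. What is called first, only, known or untested is meant among the compounds shown, and "the series" means these compounds.

Compound 1 `Fc1ccc(Nc2cc3[nH]c(Nc4cc(N5CCNCC5)ccn4)nc3cn2)cc1C(F)(F)F`: 98%
Compound 2 `Fc1ccc(Nc2cc3[nH]c(Nc4ccc(N5CCN(CC6CC6)CC5)cn4)nc3cn2)cc1C(F)(F)F`: 52%
Compound 3 `Fc1ccc(Nc2cc3[nH]c(Nc4ccc(N5CCN(CC6CC6)CC5)cn4)nc3cn2)cc1F`: 7%

In an ADME assay on microsomes from liver (Homo sapiens) for metabolic stability, read by LC-MS, using NADPH, with a stated time of 60 min, tested at 0.1 uM (a higher number here means that more of the compound is left, a lower number that less of the compound is left), compound 3 gives 7%, the lowest of the three numbers and beyond the scatter from both others. The next compound is compound 4 `Fc1ccc(Nc2cc3[nH]c(Nc4ccc(C5CCNCC5)cn4)nc3cn2)cc1F`. Its change from compound 3 is piperidin-4-yl in place of 4-(cyclopropylmethyl)piperazin-1-yl on an aromatic carbon.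

Among the measured compounds shown here, no measured step covers this swap. For the measured compounds named here, the one step available, a number 45 percentage points lower from compound 2 to compound 3 (beyond the scatter), was large, but it concerns fluoro in place of trifluoromethyl, a different change. Going by the values given here, it shows only that a single change can move this read-out far. A weaker hint comes from compound 1, which gives 98% and has no cyclopropylmethyl group, but it also differs from compound 3 elsewhere.

A large upward move is therefore expected, with much uncertainty. The estimated step is a number 33 percentage points higher from compound 3 to compound 4 (beyond the scatter). For compound 4 the estimated value is 40%, with an expected range from 12% to 80%.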

Compound 4, percent of the compound remaining: 98%
Compound 4: the middle estimate sits 58 percentage points below what was measured; measured number outside the range, above it.
By their numbers in this assay, from the lowest: compound 3; then compound 2; then compounds 1 and 4 (each within the scatter of the next).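

In this assay, the exchange on this aromatic carbon, two atoms from the ring nitrogen, gives a number 91 percentage points higher from compound 3 to compound 4 (beyond the scatter), so the group held here can by itself largely decide how much compound is left. The exchange alters several things at once: 4-(cyclopropylmethyl)piperazin-1-yl, with 10 heavy atoms and a three-membered ring, gives way to piperidin-4-yl, with 6 heavy atoms and no such ring. Nothing measured here explains the rise.

The compounds shown leave open which part of the exchange carries this step, a question that plain piperazin-1-yl or 1-(cyclopropylmethyl)piperidin-4-yl at this position could help separate. Going by these compounds, it also remains open how a morpholin-4-yl group would behave here, and whether the same exchange would give a similar step with trifluoromethyl in place of fluoro.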